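The source may report more compounds than this note shows. Statements on the series, on what has been measured and on what is new or still open speak of the compounds shown alone.

Measured compounds, an assay on cells for inhibition of cytochrome P450 11B2, mitochondrial (Homo sapiens), read by HTRF (on this read-out higher numbers stand for weaker inhibition and lower numbers for stronger inhibition), read-out:

compound 1 `CC(=O)N[C@@H]1CCCc2c1cncc2N1C(=O)c2ccc(Cl)cc2[C@H]1C`: 130 nM
compound 2 `CCC(=O)N[C@@H]1CCCc2c1cncc2N1C(=O)c2ccc(Cl)cc2[C@@H]1C`: 6 nM
compound 3 `CCC(=O)N[C@@H]1CCCc2c1cncc2N1C(=O)c2ccc(Cl)cc2[C@@H]1CC`: 12 nM

In this assay compound 2 gives the lowest of the three numbers. Compound 3 sits nearest, with a 2.0-fold higher number from compound 2 to compound 3 (0.30 log units; within the scatter), a step that changes nothing of note. Among the compounds with values here, compound 1 lies furthest away; in this assay compound 1 gives 130 nM, which is well beyond the scatter from compound 2, though no single-point step connects these two compounds.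

The step under consideration goes from compound 2 to compound 4 `CCC(=O)N[C@@H]1CCCc2c1cncc2N1C(=O)c2ccc(Cl)cc2[C@H]1C`. the two compounds have the same atoms and bonds and differ only in configuration as drawn: 1 of 2 stereo elements differ; a stereocentre at a saturated ring carbon is drawn S in compound 2 and R in compound 4

Within the data shown here, no measured step in this set isolates a change of configuration, so the step bears on nothing directly comparable. Among the measured compounds shown here, the one measured step, from compound 2 to compound 3, concerns a chain substituent and stays within the scatter, which says nothing about a stereocentre. For the measured compounds named here, compound 1, the only other number, lies far from compound 2 and shows that the series can spread widely. A change of configuration at a ring stereocentre is taken here as likely to move the number, and with compound 2 holding the lowest value, the expected direction is upward. The step from compound 2 to compound 4 is estimated at a 10-fold higher number from compound 2 to compound 4 (1.00 log units; beyond the scatter). For compound 4 the estimated value in this assay is 60 nM, with a range from 15 nM to 300 nM.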

Compound 4, half-maximal inhibitory concentration: 66 nM
Estimate against measurement, compound 4: 1.1-fold (0.04 log units) below; low and high end bracket the measured number.
By their numbers in this assay, from the lowest: compounds 2 and 3 (each within the scatter of the next); then compounds 4 and 1 (each within the scatter of the next).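

In this assay, within the data shown here, a change at one stereocentre, a saturated ring carbon drawn S then R, gives an 11-fold higher number from compound 2 to compound 4 (1.04 log units; beyond the scatter), the first measured step on configuration, and nothing else in the structure can account for it: the fact that compounds 2 and 4 differ only in the configuration as drawn. With that configuration held as in compound 4, methyl in place of hydrogen on a saturated chain carbon bound to a carbonyl carbon gives a 2.0-fold lower number from compound 1 to compound 4 (0.29 log units; within the scatter), so this change does not separate the two compounds. Read together with the methyl step on the core of compound 2, the two results do not agree as a single trend: the same change on two cores in this assay, a 2.0-fold higher number (0.30 log units; within the scatter) from compound 2 to compound 3 and a 2.0-fold lower number (0.29 log units; within the scatter) from compound 1 to compound 4, 3.9-fold (0.60 log units) apart, beyond the scatter of two such steps.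

On these data alone, the other stereo element is drawn the same in all the compounds, so its contribution remains open. Also open, as far as these compounds go, is how a longer chain on the carbonyl, or a hydroxyl group on that chain, would behave under either configuration.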